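This account rests on a few compounds, and the source may have more. Where it says the series, first, only, none or still open, it means among the compounds named here.

Measured so far:
compound 1, `CC(=O)OC/C(=C\C1CCCCC1)C(=O)c1ccccc1`: 21000 nM
compound 2, `CC(=O)OC/C(=C\c1ccccc1Br)C(=O)c1ccccc1`: 21000 nM

In a functional assay on WiDr cells (Homo sapiens) for inhibition, read by sulforhodamine B assay, with a stated time of 48 h (a higher number here means a weaker inhibitor of growth, a lower number a stronger inhibitor of growth), compound 1 gives 21000 nM, and compound 2 gives 21000 nM. The one measured step, no change at the digits printed from compound 1 to compound 2 (within the scatter), swapped a cyclohexyl for a 2-bromophenyl on the double-bonded chain carbon, so compound 2 stands level with compound 1 on the numbers shown.

Compound 3, `CC(=O)OC/C(=C/c1ccccc1Br)C(=O)c1ccccc1`, is the next step. Its difference from compound 2 is the two compounds have the same atoms and bonds and differ only in configuration as drawn: 1 of 1 stereo elements differ; a double bond is drawn E in compound 2 and Z in compound 3: the same atoms and bonds, only the double bond drawn the other way. Among the compounds with values here, no measured step touches the geometry of that double bond; the single step in hand exchanged a substituent and left growth inhibition unchanged, so it offers only weak guidance. With nothing pointing either way, the expected step of no change at the digits printed from compound 2 to compound 3 (within the scatter) in this assay is none beyond the scatter, held with low confidence. Compound 3 is therefore estimated at 21000 nM, with a range from 6000 nM to 70000 nM.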

Compound 3, concentration for 50% growth inhibition: 18000 nM
For compound 3 the middle estimate is 1.2-fold (0.07 log units) above the measured one; low and high end bracket the measured number.
By their numbers in this assay, from the lowest: compounds 3, 1 and 2 (each within the scatter of the next).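

Until now, only the group on the double-bonded chain carbon had been exchanged; this pair tests the geometry of the double bond itself, and the comparison isolates that one feature: the fact that compounds 2 and 3 differ only in the configuration as drawn. In this assay, the outcome is a 1.2-fold lower number from compound 2 to compound 3 (0.07 log units; within the scatter). With the 2-bromophenyl group in place, therefore, the drawn geometry of the double bond does not separate the two compounds at the level this assay can resolve.

Whether that holds for the cyclohexyl series remains open, as compound 1 is the only cyclohexyl compound shown and it carries a single geometry. Also open, from the compounds shown here alone, is how growth inhibition would respond to a different group at this position, such as an amine or a carboxylic acid, or to a hydroxyl group in place of the acetate ester.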